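The compounds below may be only part of what the source reports. "The series", "measured", "known", "first", "only" and "open" are said of these compounds alone.

Measured so far in an ADME assay on L132 cells (Homo sapiens) for cytotoxicity, read by MTT assay, with a stated time of 48 h; on this read-out lower numbers stand for stronger inhibition and higher numbers for weaker inhibition:

compound 1 `C/C(=C\CC/C(C)=C/CC[C@@H]1[C@@]2(C)CCC(=O)C(C)(C)[C@H]2CC[C@@]1(C)O)CC/C=C(\C)C(=O)OCc1cn(-c2ccc([N+](=O)[O-])cc2)nn1` — > 150000 nM, a limit of the assay
compound 2 `C/C(=C\CC/C(C)=C/CC[C@@H]1[C@@]2(C)CCC(=O)C(C)(C)[C@H]2CC[C@@]1(C)O)CC/C=C(\C)C(=O)OCc1cn(-c2ccc(F)c(Cl)c2)nn1` — > 150000 nM, a limit of the assay
compound 3 `C/C(=C\CC/C(C)=C/CC[C@@H]1[C@@]2(C)CCC(=O)C(C)(C)[C@H]2CC[C@@]1(C)O)CC/C=C(\C)C(=O)OCc1cn(-c2ccccc2F)nn1` — > 150000 nM, a limit of the assay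

Compound 1 stands at the limit of this assay; no number is known for it, only that it sits at the limit of > 150000 nM in this assay, at which 3 of the 3 values shown sit. The same holds for compound 2 and compound 3, so the three measured steps, a step that the two limits leave unreadable from compound 1 to compound 2, a step that the two limits leave unreadable from compound 1 to compound 3 and a step that the two limits leave unreadable from compound 2 to compound 3, are all unreadable from the two limits: they tell neither size nor direction.

Compound 4 `C/C(=C\CC/C(C)=C/CC[C@@H]1[C@@]2(C)CCC(=O)C(C)(C)[C@H]2CC[C@@]1(C)O)CC/C=C(\C)C(=O)OCc1cn(-c2ccc(C(C)(C)C)cc2)nn1` differs from compound 1 in tert-butyl in place of nitro on an aromatic carbon. Among the compounds with values here, none of the measured steps touches this position; each of them swaps the whole ring on the aromatic nitrogen, and none gives a readable size. Within the data shown here, there is thus nothing among the measured compounds that would set compound 4 apart from compound 1 in this assay, and the expectation is that compound 4 also comes out at the limit.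

The step from compound 1 to compound 4 is expected as a step that the limit leaves unreadable from compound 1 to compound 4, which cannot be read against a limit. Compound 4 is estimated at 200000 nM, with a range from 100000 nM to 600000 nM.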

Compound 4, half-maximal inhibitory concentration: 65800 nM
Beside the measured number, compound 4's estimate is 3.0-fold (0.48 log units) above it; measured number outside the range, below it.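

In this assay, within the data shown here, tert-butyl in place of nitro on an aromatic carbon gives an at least 2.2-fold lower number from compound 1 to compound 4 (0.35 log units; beyond the scatter), the first readable step and the first sign that the group on this ring can shift the read-out. Exchanging the whole ring on the aromatic nitrogen for 4-(tert-butyl)phenyl gives an at least 2.2-fold lower number from compound 2 to compound 4 (0.35 log units; beyond the scatter) and an at least 2.2-fold lower number from compound 3 to compound 4 (0.35 log units; beyond the scatter), while the steps among the other three compounds cannot be read in either size or direction. Of the four compounds, only compound 4 has a number; compound 1, compound 2 and compound 3 all remain at a limit of the assay: the limit of > 150000 nM in this assay, at which 3 of the 4 values shown sit.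

As far as these compounds go, each of the three new steps has a limit at one end, and its full size remains open. Also open, from the compounds shown here alone, is whether the lower number belongs to tert-butyl alone, or whether a methyl group, an amine or a carboxylic acid on the same aromatic carbon would also bring a compound off the limit.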